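Swapping 3,5-dimethylpiperazin-1-yl for piperidin-4-yl in compound 2

The source may hold more compounds than are shown below. What is called first, only, known or untested is meant among the compounds shown, and "the series" means these compounds.

In an ADME assay on microsomes from liver (Mus musculus) for metabolic stability, read by LC-MS, using NADPH, with a stated time of 60 min, tested at 0.1 uM (a lower number here means that less of the compound is left, a higher number that more of the compound is left), compound 1 (`Fc1ccc(Nc2cc3[nH]c(Nc4ccc(N5CCN(CC6CC6)CC5)cn4)nc3cn2)cc1F`) gives 14% and compound 2 (`C[C@@H]1CN(c2ccc(Nc3nc4cnc(Nc5ccc(F)c(F)c5)cc4[nH]3)nc2)C[C@H](C)N1`) gives 76% as the highest of the two numbers. Among the measured compounds shown here, the one measured step is a number 62 percentage points higher from compound 1 to compound 2 (beyond the scatter) and it is large and beyond the scatter. In that step, 3,5-dimethylpiperazin-1-yl stands in place of 4-(cyclopropylmethyl)piperazin-1-yl on an aromatic carbon. Compound 3 (`Fc1ccc(Nc2cc3[nH]c(Nc4ccc(C5CCNCC5)cn4)nc3cn2)cc1F`) differs from compound 2 at that same place (piperidin-4-yl in place of 3,5-dimethylpiperazin-1-yl on an aromatic carbon) with piperidin-4-yl in place of 3,5-dimethylpiperazin-1-yl on an aromatic carbon. For the measured compounds named here, the measured step bears on this change only in part: it shows how far one swap at this place moved the number, but no measured compound carries piperidin-4-yl. Compound 2 with 76% is therefore the starting point, and a step of the earlier size is not expected. A small downward step is expected, estimated as a number 10 percentage points lower from compound 2 to compound 3 (within the scatter) in this assay on the evidence so far. Compound 3 is estimated at 66% within an expected range of 40% to 88% for this measurement.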

Compound 3, percent of the compound remaining: 87%
Beside the measured number, compound 3's estimate is 21 percentage points below it, and the stated range covers the measured number.
By their numbers in this assay, from the lowest: compound 1; then compound 2; then compound 3.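

In this assay, the move to piperidin-4-yl gives a number 11 percentage points higher from compound 2 to compound 3 (beyond the scatter), a modest step, so on this aromatic carbon, para to a large group, a high number does not depend on the second ring nitrogen or on the two defined stereocentres of 3,5-dimethylpiperazin-1-yl. Set against 4-(cyclopropylmethyl)piperazin-1-yl, the same group gives a number 73 percentage points higher from compound 1 to compound 3 (beyond the scatter), which shows that two different six-membered non-aromatic rings, each with one hydrogen-bond donor, both stand far above compound 1 at this place, with piperidin-4-yl the higher of the two. No information is available on why the number moves in either step.

Still open, going by these compounds, is whether the low number of compound 1 goes with the cyclopropylmethyl group itself or with any substituent on that ring nitrogen, a question that a methyl or an acetyl on the nitrogen of piperidin-4-yl would address. Also open, on these data alone, is whether the ring nitrogen is needed at all at this position, which a morpholin-4-yl or a cyclohexyl group in the same place would test.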